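From 4-fluorophenyl to 3,4-dimethoxyphenyl: one open measurement

The source may hold more compounds than are shown below. What is called first, only, known or untested is meant among the compounds shown, and "the series" means these compounds.

Compound 1 (`Cc1ccc2[nH]c(-c3ccc(-c4ccc(-c5cccc(Cl)c5)cc4)cc3)nc2c1`): 2780 nM
Compound 2 (`Fc1ccc(-c2ccc(-c3ccc(-c4nc5ccccc5[nH]4)cc3)cc2)cc1`): 100000 nM

In a functional assay on COLO 205 cells (Homo sapiens) for inhibition, read by sulforhodamine B assay (on this read-out higher numbers stand for weaker inhibition of growth and lower numbers for stronger inhibition of growth), compound 1 gives 2780 nM. Compound 2 has the higher of the two numbers, and the gap between the two lies beyond the scatter. Compound 3 (`COc1ccc(-c2ccc(-c3ccc(-c4nc5ccccc5[nH]4)cc3)cc2)cc1OC`) carries 3,4-dimethoxyphenyl in place of 4-fluorophenyl on an aromatic carbon. Among the compounds with values here, no measured pair shows this change alone, so the expectation is loose. Since compound 2 gives 100000 nM in this assay a moderate move to a lower number, meaning stronger inhibition of growth, is expected. An estimated 4.0-fold lower number from compound 2 to compound 3 (0.60 log units; beyond the scatter) is the expected size of that move. Compound 3 is estimated at 25000 nM (range 4000 nM to 100000 nM).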

Compound 3, concentration for 50% growth inhibition: 41200 nM
Beside the measured number, compound 3's estimate is 1.6-fold (0.22 log units) below it; the measured number falls inside the stated range.
By their numbers in this assay, from the lowest: compound 1; then compound 3; then compound 2.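

In this assay the swap of 4-fluorophenyl for 3,4-dimethoxyphenyl gives a 2.4-fold lower number from compound 2 to compound 3 (0.39 log units; beyond the scatter) and so a modest gain in inhibition of growth. Within the data shown here, this is the first single change measured at this position, and it shows that the read-out responds to the group placed there, with a step that lies beyond the scatter. No available evidence accounts for the step.

The compounds shown leave open whether one methoxy group alone would give the same move. They also leave open how an amine or a carboxylic acid at this position would compare.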